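The source may hold more compounds than are shown below. What is called first, only, known or untested is meant among the compounds shown, and "the series" means these compounds.

In a physicochemical assay for lipophilicity, at pH 7.4 (a lower number here means a more polar compound, a higher number a more lipophilic compound), the measured compounds stand as follows

- compound 1 `Cc1ccc(N(C2CCC2)S(=O)(=O)c2ccc3c(c2)C(O)CC(C2CCOCC2)O3)c(C)c1` gives 3.77
- compound 2 `CC(C)CN(c1ccccc1F)S(=O)(=O)c1ccc2c(c1)C(O)CC(C1CCOCC1)O2` gives 3.39
- compound 3 `CC(C)CN(c1ccc(F)cc1F)S(=O)(=O)c1ccc2c(c1)C(O)CC(C1CCOCC1)O2` gives 3.53

At 3.53 compound 3 lies within the usual scatter of both other compounds, so it cannot be firmly ranked against either of them. The next compound, compound 4 `Cc1ccc(N(CC(C)C)S(=O)(=O)c2ccc3c(c2)C(O)CC(C2CCOCC2)O3)c(C)c1`, differs from compound 3 in one place. The change is 2,4-dimethylphenyl in place of 2,4-difluorophenyl on a sulfonamide nitrogen and, in words, it puts 2,4-dimethylphenyl in place of 2,4-difluorophenyl on a sulfonamide nitrogen.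

Among the compounds with values here, only one measured step comes close to this change. It is a number 0.14 log units higher from compound 2 to compound 3 (within the scatter) for fluoro in place of hydrogen on an aromatic carbon, a small move that shows how little one such swap shifted the number. Within the data shown here, no measured pair shows fluoro giving way to methyl directly. Among the measured compounds shown here, the best remaining clue is compound 1, the only measured compound with the 2,4-dimethylphenyl group, which gives 3.77 with a different group on its sulfonamide nitrogen. That value hints weakly at an upward direction. The expected step is a number 0.27 log units higher from compound 3 to compound 4 (within the scatter) in this assay and it is modest. Compound 4 is therefore estimated at 3.8 (range 3.5 to 4.1).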

Compound 4, distribution coefficient: 4.19
Estimate against measurement, compound 4: 0.39 log units below, outside the stated range (above it).
By their numbers in this assay, from the lowest: compounds 2, 3 and 1 (each within the scatter of the next, the first and the last beyond it); then compound 4.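

In this assay, within the data shown here, with the isobutyl group kept, putting 2,4-dimethylphenyl in place of 2,4-difluorophenyl on the sulfonamide nitrogen gives a number 0.66 log units higher from compound 3 to compound 4 (beyond the scatter) as the first direct reading of this swap, and the same group replacing 2-fluorophenyl gives a number 0.80 log units higher from compound 2 to compound 4 (beyond the scatter) on that nitrogen. Among these compounds, the aromatic group at this position can therefore move the number beyond the scatter, which the only earlier step there, a number 0.14 log units higher from compound 2 to compound 3 (within the scatter) for one added fluoro, did not show. The other group on this nitrogen also counts, since with 2,4-dimethylphenyl held constant, isobutyl in place of cyclobutyl gives a number 0.42 log units higher from compound 1 to compound 4 (beyond the scatter) as a separate step of its own.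

From the compounds shown here alone, it remains open how the rise divides between the two methyl groups, and how a phenyl ring carrying chloro or methoxy, or a chain ending in an amine, would read on this nitrogen in this assay. No measurement shown here gives a cause for these steps.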